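Replacing the methoxy group of compound 2

This account rests on a few compounds, and the source may have more. Where it says the series, first, only, none or still open, it means among the compounds named here.

In a functional assay on HCT-116 cells (Homo sapiens) for antiproliferative activity, read by MTT assay, with a stated time of 72 h (on this read-out higher numbers stand for weaker inhibition and lower numbers for stronger inhibition), compound 1 `O=C(CCc1cccc2c1B(O)OC2)Nc1ccc(Br)cc1` gives 46000 nM. Compound 2 `COc1ccc(NC(=O)CCc2cccc3c2B(O)OC3)cc1` shares its core and gives 1700 nM, the lowest of the two numbers. Putting methoxy in place of bromo on an aromatic carbon accounts for a 27-fold lower number from compound 1 to compound 2 (1.43 log units; beyond the scatter), a large step beyond the scatter.

Compound 3 `CC(C)(C)OC(=O)NCc1ccc(NC(=O)CCc2cccc3c2B(O)OC3)cc1` has ((tert-butoxycarbonyl)amino)methyl in place of methoxy on an aromatic carbon, para to a large group: ((tert-butoxycarbonyl)amino)methyl in place of methoxy on an aromatic carbon.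

For the measured compounds named here, only one measured step bears on this change. That step, a 27-fold lower number from compound 1 to compound 2 (1.43 log units; beyond the scatter), shows that swapping a single group on this ring can move the number a long way. Going by the values given here, it cannot give a direction for the new group, since no compound with a similar group has been measured. Among the compounds with values here, with compound 2 at 1700 nM, the lower of only two numbers, a moderate rise is expected rather than a further fall, and a smaller shift than the measured step. The expected change is a 2.9-fold higher number from compound 2 to compound 3 (0.47 log units; beyond the scatter). For compound 3 the estimate is 5000 nM, with an expected range of 900 nM to 30000 nM.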

Compound 3, half-maximal inhibitory concentration: 2300 nM
Estimate against measurement, compound 3: 2.2-fold (0.34 log units) above; the range from low to high includes it.
By their numbers in this assay, from the lowest: compounds 2 and 3 (each within the scatter of the next); then compound 1.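

At this position, on an aromatic carbon para to a large group, this assay does not separate methoxy, with 2 heavy atoms, from ((tert-butoxycarbonyl)amino)methyl, with 9 heavy atoms and a hydrogen-bond donor that methoxy lacks: the step is a 1.4-fold higher number from compound 2 to compound 3 (0.13 log units; within the scatter). The large step seen earlier is therefore not unique to methoxy, since a second, very different group replacing bromo gives a 20-fold lower number from compound 1 to compound 3 (1.30 log units; beyond the scatter), and among these three compounds bromo is the one that stands apart. The data offer no measurement that would explain why these two groups cannot be told apart or why bromo differs from both.

The compounds shown leave open whether compound 3 keeps its place in this assay when the carbamate is replaced by a free aminomethyl group or a carboxylic acid, which would show whether the tert-butoxycarbonyl part matters at all. They also leave open whether chloro or fluoro in place of methoxy would give a number near that of compound 1, or whether bromo alone stands apart.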